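Swapping Fluoro for Bromo: An Expected Cytotoxicity Value

A few compounds are considered here, and "the series" means these few. Any claim that something is new, unique, unknown or untested is made for them only; others in the source may bear on it.

compound 1 `CC(O)Cn1c([N+](=O)[O-])cnc1/C=C/c1ccc(Br)cc1`: 550 nM
compound 2 `CC(O)Cn1c([N+](=O)[O-])cnc1/C=C/c1ccccc1F`: 1410 nM

In an ADME assay on cells (Macrophage, Homo sapiens) for cytotoxicity, read by MTT assay, with a stated time of 24 h (on this read-out lower numbers stand for higher toxicity in this test and higher numbers for lower toxicity in this test), compound 2 gives the higher of the two numbers, a 2.6-fold higher number from compound 1 to compound 2 (0.41 log units; beyond the scatter). Compound 3 `CC(O)Cn1c([N+](=O)[O-])cnc1/C=C/c1ccccc1Br` differs from compound 2 by bromo in place of fluoro on an aromatic carbon. Going by the values given here, no measured step changes only the halogen at a fixed place; the one step measured, between compound 1 and compound 2, alters both the halogen and where it sits, so it bears on the new change only loosely. In this assay a small downward step, a 1.6-fold lower number from compound 2 to compound 3 (0.19 log units; within the scatter), is expected, but it may stay within the scatter. For compound 3 the estimate is 900 nM, ranging from 400 nM to 2500 nM.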

Compound 3, half-maximal cytotoxic concentration: 490 nM
Compound 3: middle estimate off by 1.8-fold (0.26 log units), on the high side; the measured number falls inside the stated range.
By their numbers in this assay, from the lowest: compounds 3 and 1 (each within the scatter of the next); then compound 2.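

With the place held fixed, the change from fluoro to bromo can now be read alone: in this assay it gives a clear drop (a 2.9-fold lower number from compound 2 to compound 3 (0.46 log units; beyond the scatter)). Moving the bromo from 4-bromophenyl to 2-bromophenyl leaves the two compounds indistinguishable (a 1.1-fold lower number from compound 1 to compound 3 (0.05 log units; within the scatter)), so among these three compounds the number follows which halogen is present, not where the bromo sits. Nothing measured here explains this. Open, on these data alone, is where chloro, or a non-halogen such as methoxy or an amine, would fall at this place. Also open, as far as these compounds go, is whether a fluoro on the 4-position would match the 2-fluorophenyl compound.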